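Removing a Methyl from the Ring Oxygen

The source may hold more compounds than are shown below. What is called first, only, known or untested is meant among the compounds shown, and "the series" means these compounds.

Of the compounds shown here, two have been measured in a functional assay on SW-620 cells (Homo sapiens) for inhibition, read by sulforhodamine B assay, with a stated time of 48 h; a lower number here means a stronger inhibitor of growth, a higher number a weaker inhibitor of growth. Compound 2 `COc1cc(C)cc(-c2nn(CC#N)cc2-c2ccnc(-c3ccc(N(C)C)cc3)c2)c1` gives 332 nM, the lower of the two numbers. Within the data shown here, compound 1 `Cc1cc(O)cc(-c2nn(CC#N)cc2-c2ccnc(-c3ccc(Oc4ccccc4)cc3)c2)c1` gives 1940 nM; it differs from compound 2 in two places, so no single step connects them. Compound 3 `Cc1cc(O)cc(-c2nn(CC#N)cc2-c2ccnc(-c3ccc(N(C)C)cc3)c2)c1` is compound 2 with hydrogen in place of methyl on an oxygen on an aromatic ring. Among the measured compounds shown here, no measured pair shows this change alone. A step from compound 2 to compound 3 of a 1.8-fold higher number from compound 2 to compound 3 (0.26 log units; within the scatter) is expected, a mild weakening near the scatter. Compound 3 is expected to give 600 nM, between 200 nM and 2000 nM.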

Compound 3, concentration for 50% growth inhibition: 2830 nM
Compound 3: the middle estimate sits 4.7-fold (0.67 log units) below what was measured, and the stated range ends below it.
By their numbers in this assay, from the lowest: compound 2; then compounds 1 and 3 (each within the scatter of the next).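

In this assay, the methyl on this oxygen carries real weight: methoxy to hydroxy gives a step (an 8.5-fold higher number from compound 2 to compound 3 (0.93 log units; beyond the scatter)) larger than the first two compounds could suggest. Once hydroxy is present, dimethylamino in place of phenoxy gives only a step within the scatter (a 1.5-fold higher number from compound 1 to compound 3 (0.16 log units; within the scatter)), so these two groups cannot be told apart in this setting. Nothing available here explains the size of the methoxy to hydroxy step. As far as these compounds go, whether ethoxy or an amine on that ring carbon would match methoxy remains open. So does whether phenoxy and dimethylamino would still match alongside methoxy.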